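From a Difluoropiperidine Urea to a Propargyl Urea

The source may report more compounds than this note shows. Statements on the series, on what has been measured and on what is new or still open speak of the compounds shown alone.

Compound 3 `O=C(Nc1cc2c(Nc3ccc(F)c(Cl)c3)ncnc2cc1O[C@H]1CCOC1)N1CCC(F)(F)CC1` gives 1860 nM in a functional assay on A-431 cells (Homo sapiens) for antiproliferative activity, read by sulforhodamine B assay, with a stated time of 72 h (a higher number here means a weaker inhibitor, a lower number a stronger inhibitor), the second-highest of the three numbers measured: compound 1 `COCCCNC(=O)Nc1cc2c(Nc3ccc(F)c(Cl)c3)ncnc2cc1O[C@H]1CCOC1` gives 4100 nM and compound 2 `CN(C)CCN(C)C(=O)Nc1cc2c(Nc3ccc(F)c(Cl)c3)ncnc2cc1O[C@H]1CCOC1` gives 450 nM. Compound 4 `C#CCNC(=O)Nc1cc2c(Nc3ccc(F)c(Cl)c3)ncnc2cc1O[C@H]1CCOC1` differs from compound 3 by propargylamino in place of 4,4-difluoropiperidin-1-yl on a carbonyl carbon. The step that bears most directly on this is a 2.2-fold lower number from compound 1 to compound 3 (0.34 log units; beyond the scatter), where an open-chain amino group on a carbonyl carbon gave way to the cyclic amine; the present change reverses that kind of move. The step of a 4.1-fold higher number from compound 2 to compound 3 (0.62 log units; beyond the scatter) shows the larger shift belonged to the amine-bearing chain, which compound 4 does not carry. A modest move to a higher number is therefore expected, a 1.6-fold higher number from compound 3 to compound 4 (0.21 log units; within the scatter). For compound 4 the estimate in this assay is 3000 nM, with a range from 1000 nM to 9000 nM.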

Compound 4, half-maximal inhibitory concentration: 3730 nM
Compound 4: the middle estimate sits 1.2-fold (0.09 log units) below what was measured; the measured number falls inside the stated range.
By their numbers in this assay, from the lowest: compound 2; then compounds 3, 4 and 1 (each within the scatter of the next, the first and the last beyond it).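

In this assay the propargylamino group on the carbonyl carbon is level with the 4,4-difluoropiperidin-1-yl group (a 2.0-fold higher number from compound 3 to compound 4 (0.30 log units; within the scatter)) and with the (3-methoxypropyl)amino group (a 1.1-fold lower number from compound 1 to compound 4 (0.04 log units; within the scatter)), so ring and open chain are not told apart here. Only the (2-(dimethylamino)ethyl)(methyl)amino group of compound 2 stands apart (an 8.3-fold higher number from compound 2 to compound 4 (0.92 log units; beyond the scatter)). No evidence on the reason for these numbers is at hand. Still open, going by these compounds, is whether a (2-(dimethylamino)ethyl)amino group, without the methyl on its urea nitrogen, would match compound 2. On these data alone, a morpholine or pyrrolidine at the chain end is equally open.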